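Swapping chloro for (dimethylamino)methyl on the aryl arm

The source may hold more compounds than are shown below. What is called first, only, known or untested is meant among the compounds shown, and "the series" means these compounds.

Measured compounds:
compound 1, `Cn1nc2c(=O)n(CC3(O)CCN(Cc4ccc(-c5n[nH]c(=O)o5)cc4Cl)CC3)cnc2c1-c1ccc(CN)cc1`: 171 nM
compound 2, `Cn1nc2c(=O)n(CC3(O)CCN(Cc4ccc(-c5ccco5)cc4Cl)CC3)cnc2c1-c1ccc(Cl)cc1`: 143 nM

In an assay on isolated protein for inhibition of ubiquitin carboxyl-terminal hydrolase 7 (Homo sapiens), with stated times of 30 min and 2 h (on this read-out higher numbers stand for weaker inhibition and lower numbers for stronger inhibition), compound 2 gives 143 nM, and compound 1 gives 171 nM. The two numbers lie within the usual scatter of each other, so neither compound can be called the stronger inhibitor on this evidence. For the measured compounds named here, compound 1 and compound 2 differ in more than one place, so no single step between them can be read.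

Compound 3, `CN(C)Cc1ccc(-c2c3ncn(CC4(O)CCN(Cc5ccc(-c6ccco6)cc5Cl)CC4)c(=O)c3nn2C)cc1`, has not yet been tested. Compared with compound 2, the change is (dimethylamino)methyl in place of chloro on an aromatic carbon: (dimethylamino)methyl in place of chloro, on an aromatic carbon of a six-membered aromatic ring of carbon only, para to a large group. Going by the values given here, no measured pair shows this exact exchange, so there is no step to lean on. The expectation for the step from compound 2 to compound 3 in this assay is a 1.0-fold higher number from compound 2 to compound 3 (0.02 log units; within the scatter), that is, nothing beyond the scatter in either direction. Compound 3 is therefore estimated at 150 nM, with a range from 50 nM to 450 nM.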

Compound 3, half-maximal inhibitory concentration: 131 nM
Beside the measured number, compound 3's estimate is 1.1-fold (0.06 log units) above it, and the stated range covers the measured number.
By their numbers in this assay, from the lowest: compounds 3, 2 and 1 (each within the scatter of the next).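

In this assay, replacing chloro with (dimethylamino)methyl gives a 1.1-fold lower number from compound 2 to compound 3 (0.04 log units; within the scatter). This is the only single-place step shown, and it gives the first direct reading at this position, on an aromatic carbon para to a large group. Here, 4 heavy atoms, including 1 hydrogen-bond acceptor, enter in place of 1 heavy atom without moving the number beyond the scatter, and nothing measured here offers an explanation for this result.

The compounds shown leave open whether a carboxylic acid or a morpholinomethyl group at the same place would also stay within the scatter. As far as these compounds go, the separate contribution of the aryl substituent in compound 1 also remains unknown, since that compound differs from compound 2 and compound 3 in more than one place.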